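The source may report more compounds than this note shows. Statements on the series, on what has been measured and on what is new or still open speak of the compounds shown alone.

Measured so far:
compound 1 `CC1(C)Cc2c(ccc(C(=O)/C=C/c3ccc(Cl)cc3)c2OCc2ccccc2)O1`: > 100000 nM
compound 2 `CC1(C)Cc2c(ccc(C(=O)/C=C/c3cn(-c4ccccc4)nc3-c3ccc(Cl)cc3)c2OCc2ccccc2)O1`: > 100000 nM
compound 3 `COc1ccc(/C=C/C(=O)c2ccc(OCc3ccccc3)c3c2OC(C)(C)C3)cc1`: > 100000 nM

In a functional assay on NCI-H460 cells (Homo sapiens) for antiproliferative activity, read by MTT assay, with a stated time of 48 h (a higher number here means a weaker inhibitor, a lower number a stronger inhibitor), compound 2 gives > 100000 nM, which is a limit of the assay and not a number. Compound 1 likewise gives only a limit, > 100000 nM. Compound 3 also gives only a limit, > 100000 nM. Every value shown so far sits at the limit of > 100000 nM in this assay, at which 3 of the 3 values shown sit, so compound 2 cannot be placed relative to the others beyond sharing that limit.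

Compound 4 `Cc1ccc(-c2nn(-c3ccccc3)cc2/C=C/C(=O)c2ccc3c(c2OCc2ccccc2)CC(C)(C)O3)cc1` differs from compound 2 in one place: methyl in place of chloro on an aromatic carbon. No measured step of this kind exists in the series, and nothing shown argues for a change in this assay beyond the scatter. Compound 4 is therefore expected to remain at the limit, with an estimate of 150000 nM (range 50000 nM to 500000 nM). The expected step is a step that the limit leaves unreadable from compound 2 to compound 4.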

Compound 4, half-maximal inhibitory concentration: > 100000 nM
Compound 4 was reported as a limit (the forecaster's own chance of this, stated with the estimate: 85%); the middle value does not contradict the limit.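

No step can be read between compound 2 and compound 4, as both are reported only as limits of the assay and not as numbers: the limit of > 100000 nM in this assay, at which 4 of the 4 values shown sit.

The compounds shown leave open which structural change, if any, would bring this series off that limit.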